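Selenium to methylsulfanyl on the shared core

A few compounds are considered here, and "the series" means these few. Any claim that something is new, unique, unknown or untested is made for them only; others in the source may bear on it.

Measured so far in a functional assay on HT-29 cells (Homo sapiens) for cytotoxicity, read by MTT assay, with a stated time of 72 h; a lower number here means a stronger inhibitor of growth, a higher number a weaker inhibitor of growth:
Compound 1, `Sc1nc(NCc2ccccc2)c2ccccc2n1`: compound 1 gives 63500 nM.
Compound 2, `[SeH]c1nc(NCc2ccccc2)c2ccccc2n1`: compound 2 gives only a limit, > 100000 nM.

Compound 2 sits at the limit of > 100000 nM in this assay, at which 1 of the 2 values shown sits, so for compound 2 there is no number, only a limit. Going by the values given here, the single measured step, an at least 1.5-fold higher number from compound 1 to compound 2 (0.19 log units; that floor lies within the scatter), put selenium in place of sulfur on the shared core, and its floor lies within the scatter.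

Compound 3, `CSc1nc(NCc2ccccc2)c2ccccc2n1`, differs from compound 2 by a group of 2 heavy atoms (1 carbon, 1 sulfur; no ring) in place of one selenium atom, on an aromatic carbon. Among the compounds with values here, this change reverses the selenium-for-sulfur step of compound 1 to compound 2 and adds a methyl on the sulfur; the methyl itself has no measured counterpart. The return of sulfur is expected to bring the number back toward that of compound 1, with the methyl left open.

Compound 3 is therefore expected at about 60000 nM, between 25000 nM and 150000 nM. The expected step is an at least 1.6-fold lower number from compound 2 to compound 3 (0.22 log units; that floor lies within the scatter), from a starting point that is only a limit.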

Compound 3, concentration for total growth inhibition: > 100000 nM
Compound 3 was reported as a limit (the forecaster's own chance of this, stated with the estimate: 30%); middle value at least 1.6-fold (0.22 log units) from the limit.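

In this assay compound 3 gives only a limit, > 100000 nM, so methylsulfanyl on this aromatic carbon, between two ring nitrogen atoms, yields no number. Methyl in place of hydrogen on the sulfur gives an at least 1.5-fold higher number from compound 1 to compound 3 (0.19 log units; that floor lies within the scatter), so, as with selenium in place of sulfur, the change is not shown to go beyond the scatter. The step joining the two limits cannot be read, and only compound 1 now carries a number: the limit of > 100000 nM in this assay, at which 2 of the 3 values shown sit.

Still open, from the compounds shown here alone, is whether any other group at this position, such as an amine, a hydroxyl or a longer chain on the sulfur, would give a lower number than compound 1, which gives 63500 nM. Going by these compounds, how far compound 2 and compound 3 lie past their limits also remains open.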